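Methyl in Place of Methoxy: Expected Half-Life of Compound 4

The compounds below may be only part of what the source reports. "The series", "measured", "known", "first", "only" and "open" are said of these compounds alone.

Three compounds sharing one core have been run in an ADME assay; a lower number here means that the compound disappears faster, a higher number that the compound lasts longer. Compound 2 `COc1ccc(C[S+]([O-])c2ncccc2C(=O)Nc2ccncc2)c(OC)c1OC` gives 0.45 h. In this assay compound 1 `COc1ccc(C[S+]([O-])c2ncccc2C(=O)Nc2ccncc2)c(OC)c1C` gives 0.12 h. The change between them, (methyl in place of methoxy on an aromatic carbon), made a step of a 3.8-fold lower number from compound 2 to compound 1 (0.57 log units; beyond the scatter). Compound 3 `COc1cc(OC)c(C[S+]([O-])c2ncccc2C(=O)Nc2ccncc2)c(OC)c1` is built from the same atoms as compound 2, joined differently; the difference between the two cores is not broken down here. In this assay compound 3 reaches only a limit of the assay, < 0.02 h, the lowest readable point (the limit of < 0.02 h in this assay, at which 1 of the 3 values shown sits).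

Compound 4 `COc1cc(C)c(C[S+]([O-])c2ncccc2C(=O)Nc2ccncc2)c(OC)c1` has not yet been tested in this assay. It differs from compound 3 by methyl in place of methoxy on an aromatic carbon, the same kind of change as from compound 2 to compound 1, though here the place is ortho to a large group and meta to two methoxy groups, whereas in compound 1 it is ortho to two methoxy groups and meta to a large group. Compound 4 is expected at around 0.008 h in this assay, because the step of a 3.8-fold lower number from compound 2 to compound 1 (0.57 log units; beyond the scatter) ran toward a lower number and compound 3 already stands at the limit of < 0.02 h in this assay, at which 1 of the 3 values shown sits. That expected value means a step that the limit leaves unreadable from compound 3 to compound 4, and the result is expected most likely to be reported only as a limit.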

Compound 4, half-life: < 0.02 h
Compound 4: a limit, no number; the forecaster's own chance of this, stated with the estimate: 85%; the middle value is on the limit's open side.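

In this assay, among these compounds, compound 3 and compound 4 both end at a limit of the assay rather than a number, so no step between them can be read: the limit of < 0.02 h in this assay, at which 2 of the 4 values shown sit. The compounds shown leave open how far methyl in place of methoxy shifts the half-life in the core of compound 3, at a place ortho to a large group.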